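The compounds below may be only part of what the source reports. "The series", "measured", "known", "first", "only" and "open" are said of these compounds alone.

Measured compounds in an ADME assay on MT4 cells (Homo sapiens) for cytotoxicity, read by MTT assay, with a stated time of 4 days; a lower number here means that less compound is tolerated, a higher number that more compound is tolerated:

Compound 1, `CNc1nc(Nc2ccc(C#N)cc2)nc(Oc2ccc3ccccc3c2)n1`: 250000 nM
Compound 2, `N#Cc1ccc(Nc2nc(N)nc(Oc3ccc4ccccc4c3)n2)cc1`: 42200 nM
Compound 3, `CNc1nc(Nc2ccc(C#N)cc2)nc(Oc2ccc3cc(Br)ccc3c2Br)n1`: 92800 nM

The three measured compounds fall into two pairs built on different cores. Compound 1 and compound 2 share one core, and the difference between them is hydrogen in place of methyl on a nitrogen on an aromatic ring. That change gave a 5.9-fold lower number from compound 1 to compound 2 (0.77 log units; beyond the scatter), so compound 2 is tolerated less than compound 1 in this assay. Compound 3 carries a second core, and how that core differs from the core of compound 1 is not broken down here; its value sits between those of its two neighbours, lower than the value of compound 1 and higher than the value of compound 2, with both gaps beyond the scatter.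

Compound 4 is `N#Cc1ccc(Nc2nc(N)nc(Oc3ccc4cc(Br)ccc4c3Br)n2)cc1`, not yet measured in this assay. It differs from compound 3 by hydrogen in place of methyl on a nitrogen on an aromatic ring. The place of this change is described in the same words for both pairs, so it is the same change that turned compound 1 into compound 2. Among the measured compounds shown here, on the one measured instance, the step is expected to run in the same direction and at a similar size, giving a 5.5-fold lower number from compound 3 to compound 4 (0.74 log units; beyond the scatter), because the earlier instance gave a 5.9-fold lower number from compound 1 to compound 2 (0.77 log units; beyond the scatter). For the measured compounds named here, only one pair supports this, so the range around the expectation is kept wide. Compound 4 is therefore expected to show about 17000 nM in this assay, with the estimate spanning from 6000 nM to 50000 nM.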

Compound 4, half-maximal cytotoxic concentration: 244000 nM
Estimate against measurement, compound 4: 14-fold (1.16 log units) below, and the stated range ends below it.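

On the second core, in this assay, replacing methylamino with amino gave a 2.6-fold higher number from compound 3 to compound 4 (0.42 log units; beyond the scatter), which runs opposite to the step seen for the same change on the core of compound 1, and the two steps differ clearly: the same change on two cores in this assay, a 5.9-fold lower number (0.77 log units; beyond the scatter) from compound 1 to compound 2 and a 2.6-fold higher number (0.42 log units; beyond the scatter) from compound 3 to compound 4, 16-fold (1.19 log units) apart, beyond the scatter of two such steps

The change therefore does not carry from one core to the other in this series, since neither the direction nor the size of the step on one core held on the other. Among the compounds shown here, what the two pairs do not show is which difference between the cores goes with the reversal, or how the same change would behave on any third core, as they give only one step on each core and no compound that separates the parts in which the cores differ.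

The compounds shown leave open how a longer chain such as ethyl on that nitrogen, or a cyclic amine such as morpholine in place of methylamino, would behave on either core. They also leave open whether chlorine in place of bromine on the second core would keep the step in the direction seen there.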